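Swapping a Halogen at the Outer Ring

The source may report more compounds than this note shows. Statements on the series, on what has been measured and on what is new or still open speak of the compounds shown alone.

Among the compounds with values here, compound 2 `CCOC(=O)/C(CCCC(=O)O)=N\Nc1ccc(Br)cc1` is the only compound with a number in an assay on isolated protein for inhibition of kynurenine--oxoglutarate transaminase 1 (Homo sapiens), read by HPLC, with a stated time of 20 min (a lower number here means a stronger inhibitor, a higher number a weaker inhibitor), where compound 2 gives 21000 nM. Compound 1 `Cc1ccc2[nH]c(C(=O)O)c(CCC(=O)O)c2c1` sits at a limit of this assay, > 1000000 nM, as the limit of > 1000000 nM in this assay, at which 1 of the 2 values shown sits, records. Compound 3 `CCOC(=O)/C(CCCC(=O)O)=N\Nc1ccc(I)cc1` differs from compound 2 by iodo in place of bromo on an aromatic carbon. Within the data shown here, no measured pair shows this change, so its size has not been seen; exchanging one halogen for another here is expected to shift the value little, not beyond the usual scatter. Compound 3 is therefore estimated at 15000 nM, between 5000 nM and 50000 nM. This estimate means a step of a 1.4-fold lower number from compound 2 to compound 3 (0.15 log units; within the scatter).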

Compound 3, half-maximal inhibitory concentration: 34000 nM
Compound 3: the middle estimate sits 2.3-fold (0.36 log units) below what was measured; measured number inside the range.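

In this assay the exchange of 4-bromophenyl for 4-iodophenyl gives a 1.6-fold higher number from compound 2 to compound 3 (0.21 log units; within the scatter), so the two halogens cannot be told apart at this place on the aromatic ring. Within the data shown here, the earlier compounds offered no pair differing in one place, which makes this the first reading of any change here. Nothing shown accounts for how close the two values lie.

Still open, on these data alone, is whether this holds beyond bromo and iodo: a smaller halogen such as fluoro or chloro, or an amine or a methoxy group at the same carbon, might read differently.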